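Anilinopyrimidine series: removing the ortho chloro from compound 2

A few compounds are considered here, and "the series" means these few. Any claim that something is new, unique, unknown or untested is made for them only; others in the source may bear on it.

Among the measured compounds shown here, compound 2 `Clc1ccc(Nc2nccc(-c3ccc(Br)cc3)n2)c(Cl)c1` gives 673 nM in an assay on isolated protein for inhibition of phosphatidylinositol 4,5-bisphosphate 3-kinase catalytic subunit beta isoform (Homo sapiens) (on this read-out lower numbers stand for stronger inhibition and higher numbers for weaker inhibition), the lowest of the two numbers measured so far, with compound 1 `COc1ccc(-c2ccnc(Nc3ccc(Cl)cc3Cl)n2)cc1` nearest at 839 nM; the step of a 1.2-fold lower number from compound 1 to compound 2 (0.10 log units; within the scatter) is within the scatter. Compound 3 `Cc1ccc(-c2ccnc(Nc3ccc(Cl)cc3Cl)n2)cc1` sits at the limit of the assay, > 1000 nM, which is a limit and not a number. The steps of an at least 1.1-fold higher number from compound 1 to compound 3 (0.07 log units; that floor lies within the scatter) and an at least 1.4-fold higher number from compound 2 to compound 3 (0.17 log units; that floor lies within the scatter) are only floors because of the limit of > 1000 nM in this assay, at which 1 of the 3 values shown sits.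

Compound 4 `Clc1ccc(Nc2nccc(-c3ccc(Br)cc3)n2)cc1` differs from compound 2 by hydrogen in place of chloro on an aromatic carbon. For the measured compounds named here, none of the measured steps touches this position: all three exchange the methoxy, bromo or methyl group on the other aromatic ring and leave the dichloroanilino part unchanged. Those steps were all within the scatter or floors that lie within it, so they give no direction for the loss of a chloro group here. The expectation therefore rests on the shared dichloroanilino motif of compounds 1, 2 and 3 being the only form so far seen, and the removal of one chloro is expected to give a modest step of a 1.6-fold higher number from compound 2 to compound 4 (0.21 log units; within the scatter), with a wide range. Compound 4 is estimated at 1100 nM, between 350 nM and 3500 nM, pending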

Compound 4, half-maximal inhibitory concentration: 946 nM
The estimate for compound 4 lay 1.2-fold (0.07 log units) above the measured number, within the range that was stated.
By their numbers in this assay, from the lowest: compounds 2, 1 and 4 (each within the scatter of the next). At a limit, above all of these: compound 3.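

In this assay, among the compounds shown here, the step of a 1.4-fold higher number from compound 2 to compound 4 (0.15 log units; within the scatter) is the first reading at the ring that carries the chloro groups; the earlier steps all changed the group on the other aromatic ring. With bromo on that other ring, hydrogen can stand in place of the chloro ortho to a large group without a change beyond the scatter, so compound 2 and compound 4 read alike and this chloro is not shown to be needed for the reading. Compound 4 keeps its other chloro, so the result bears on one position only and gives no reading for this ring without any chloro.

As far as these compounds go, what an amine, a carboxylic acid or a longer chain would do in place of this chloro stays open, as does whether hydrogen in place of chloro gives a step of similar size when methoxy stands on the other ring instead of bromo. Higher numbers in this series can be followed only a short way: the limit of > 1000 nM in this assay, at which 1 of the 4 values shown sits.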